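The source may report more compounds than this note shows. Statements on the series, on what has been measured and on what is new or still open speak of the compounds shown alone.

Compound 1 `CC1(C)C=C(n2ccccc2=O)c2cc(C(=O)c3cccs3)ccc2O1` gives 6.4 in a functional assay (aorta) with Rattus norvegicus as the target; a higher number here means a more potent compound, by a factor of ten per unit of this negative logarithm, a lower number a less potent compound; compound 2 `CC1(C)C=C(n2ccccc2=O)c2cc(C(=O)c3ccc([N+](=O)[O-])cc3)ccc2O1` gives 6.2.

In this assay compound 1 and compound 2 sit within the scatter of each other, the step being a number 0.20 log units lower from compound 1 to compound 2 (within the scatter). Compound 3 `Cc1ccc(C)n1-c1ccc2c(c1)C(n1ccccc1=O)=CC(C)(C)O2` differs from compound 1 as follows: 2,5-dimethyl-1H-pyrrol-1-yl in place of (thiophen-2-yl)carbonyl on an aromatic carbon. Among the compounds with values here, no measured step covers this change; the only step known, a number 0.20 log units lower from compound 1 to compound 2 (within the scatter), concerns a different exchange on the carbonyl carbon and stays within the scatter, so the data give little guidance. Compound 3 is therefore estimated at 6, within 5.3 to 6.7, an expected step of a number 0.40 log units lower from compound 1 to compound 3 (beyond the scatter).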

Compound 3, logarithm of the reciprocal of the active concentration, log(1/C): 7.27
For compound 3 the middle estimate is 1.27 log units below the measured one; measured number outside the range, above it.
By their numbers in this assay, from the lowest: compounds 2 and 1 (each within the scatter of the next); then compound 3.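

At this aromatic carbon, 2,5-dimethyl-1H-pyrrol-1-yl in place of (thiophen-2-yl)carbonyl gives, in this assay, a number 0.87 log units higher from compound 1 to compound 3 (beyond the scatter). Unlike the exchange on the carbonyl carbon, this change moves the number beyond the scatter, and it shows that a carbonyl on this aromatic carbon is not required for a high number. The data offer no explanation for the rise.

The compounds shown leave open how an unsubstituted pyrrol-1-yl or a simple amine on this aromatic carbon would compare. On these data alone, the share of the two methyl groups in this step therefore remains unknown.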